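Ring substituent swap on the aryl ether of compound 3

This account rests on a few compounds, and the source may have more. Where it says the series, first, only, none or still open, it means among the compounds named here.

Of the compounds shown here, three have been read out in an assay for positive allosteric modulation of metabotropic glutamate receptor 3 (Rattus norvegicus) (on this read-out higher numbers stand for an effect only at larger amounts of compound and lower numbers for an effect already at smaller amounts), and they sit close together. Compound 1 `Cc1cc(C(=O)O)ccc1OC[C@H](C)COc1ccc(C(=O)CC(C)(C)C)c(O)c1C` gives 1520 nM, compound 2 `Cc1c(OC[C@@H](C)COc2ccc(C(=O)O)cc2F)ccc(C(=O)CC(C)(C)C)c1O` gives 1300 nM, and compound 3 `Cc1c(OC[C@@H](C)COc2ccc(C(=O)O)cc2Cl)ccc(C(=O)CC(C)(C)C)c1O` gives 1650 nM. Compound 3 returns the highest of the three numbers, yet its separation from compound 1 is only a 1.1-fold higher number from compound 1 to compound 3 (0.04 log units; within the scatter) and from compound 2 only a 1.3-fold higher number from compound 2 to compound 3 (0.10 log units; within the scatter), so no ordering among the three can be claimed; the remaining pair shows a 1.2-fold lower number from compound 1 to compound 2 (0.07 log units; within the scatter), likewise within the scatter.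

Compound 4 `Cc1cc(OC[C@H](C)COc2ccc(C(=O)CC(C)(C)C)c(O)c2C)ccc1C(=O)O` is not yet measured. Against compound 3 the change is 4-carboxy-3-methylphenyl in place of 4-carboxy-2-chlorophenyl on an oxygen on a saturated carbon. The measured steps that bear on it are the exchanges on this same ring: chloro for methyl in the step from compound 1 to compound 3 and chloro for fluoro in the step from compound 2 to compound 3, both within the scatter. For the measured compounds named here, compound 1 also carries a methyl and a carboxy on that ring, though arranged differently from compound 4, so no measured step covers the change exactly. With nothing in this assay moving beyond the scatter, the expected step from compound 3 to compound 4 is a 1.1-fold lower number from compound 3 to compound 4 (0.04 log units; within the scatter), meaning no change beyond the scatter. Compound 4 is therefore expected to give about 1500 nM in this assay, with a range from 700 nM to 3200 nM.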

Compound 4, half-maximal effective concentration: 1350 nM
For compound 4 the middle estimate is 1.1-fold (0.05 log units) above the measured one; low and high end bracket the measured number.
By their numbers in this assay, from the lowest: compounds 2, 4, 1 and 3 (each within the scatter of the next).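

In this assay, the 4-carboxy-3-methylphenyl group on this oxygen gives a 1.2-fold lower number from compound 3 to compound 4 (0.09 log units; within the scatter) and, against the other two aryl groups, a 1.0-fold higher number from compound 2 to compound 4 (0.02 log units; within the scatter) and a 1.1-fold lower number from compound 1 to compound 4 (0.05 log units; within the scatter) as well. For the compounds shown here, the earlier compounds changed only the substituent alongside a fixed carboxy arrangement, whereas compound 4 is the first to alter how the methyl and carboxy groups are arranged on this ring, and even that exchange stays within the scatter of all three earlier compounds, so the four compounds allow no ordering. Nothing on hand bears on why the read-out holds so steady across these aryl groups.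

The compounds shown leave open whether a larger or differently constituted substituent on this ring, such as methoxy or trifluoromethyl, would move the number beyond the scatter. They also leave open whether the carboxylic acid can give way to an amide or a tetrazole without a step of that size, since the carboxy group is present in all four compounds.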